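The source may report more compounds than this note shows. Statements on the series, on what has been measured and on what is new or still open speak of the compounds shown alone.

Measured compounds in an ADME assay on 184B5 cells (Homo sapiens) for cytotoxicity, read by sulforhodamine B assay, with a stated time of 48 h; on this read-out lower numbers stand for stronger inhibition of growth and higher numbers for weaker inhibition of growth:
- compound 1 `Cc1ccc2nc(/N=C3\C(=O)N(CN(c4ccccc4)c4ccccc4)c4ccccc43)sc2c1` — compound 1 gives 27200 nM
- compound 2 `Cc1ccc2nc(/N=C3\C(=O)N(CN4CCCCC4)c4cccc(Br)c43)sc2c1` — compound 2 gives 85200 nM
- compound 3 `CN(C)CN1C(=O)C(=O)c2c(Cl)cccc21` — compound 3 gives 130000 nM

Of the three numbers, compound 1 has the lowest. Its gap to compound 2 is beyond the scatter, and its gap to compound 3 is beyond the scatter as well, so compound 1 stands as the strongest growth inhibitor of the three in this assay. For the measured compounds named here, none of the three pairs differs in a single place, so no measured step can be drawn from them.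

The account moves from compound 1 to compound 4 `Cc1ccc2nc(/N=C3\C(=O)N(CN(c4ccccc4)c4ccccc4)c4cccc(Cl)c43)sc2c1`, which has not yet been measured in this assay. The change is chloro in place of hydrogen on an aromatic carbon. Compound 2 also carries a halogen on the same ring, but it differs from compound 1 elsewhere too, so its weaker number cannot be read as the effect of the halogen alone. Going by the values given here, with no single-point step available, a change of this kind is expected to stay within the scatter, with at most a small drift toward weaker inhibition, so the step of a 1.2-fold higher number from compound 1 to compound 4 (0.07 log units; within the scatter) is the expectation. Compound 4 is thus estimated at 32000 nM, with a range from 12000 nM to 80000 nM.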

Compound 4, concentration for 50% growth inhibition: 67800 nM
The estimate for compound 4 lay 2.1-fold (0.33 log units) below the measured number, within the range that was stated.
By their numbers in this assay, from the lowest: compound 1; then compounds 4, 2 and 3 (each within the scatter of the next).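

In this assay, chloro in place of hydrogen on this aromatic carbon, ortho to a fused ring and meta to a fused ring, gives a 2.5-fold higher number from compound 1 to compound 4 (0.40 log units; beyond the scatter), a modest weakening of growth inhibition. This is the first step in the set that changes one place only: compound 2 also carries a halogen on this ring but differs from compound 1 elsewhere, whereas here the rest of compound 1 is unchanged, so the position is shown to respond to this substitution. No measurement on hand accounts for the size or direction of the step.

On these data alone, whether a fluoro or methoxy group on this carbon would shift the number in the same direction remains open. So does whether chloro would give a similar step with the piperidine of compound 2 in place of the diphenylamino group.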